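Cytotoxicity limits across a biaryl amide series

A few compounds are considered here, and "the series" means these few. Any claim that something is new, unique, unknown or untested is made for them only; others in the source may bear on it.

Compound 3 `CCOC(=O)CCCCCOc1cccc(CN(C(=O)c2ccc(-c3cccc(S(C)(=O)=O)c3)cc2)C(C)C)c1` is one of three measured members of the series. In an ADME assay on HepG2 cells (Homo sapiens) for cytotoxicity, read by CellTiter-Glo and resazurin assay, with a stated time of 72 h (a lower number here means that less compound is needed, a higher number that more compound is needed for the effect), compound 3 reaches only the limit > 26000 nM. Compound 1 `CCOC(=O)CCCCCOc1cccc(CN(C(=O)c2ccc(-c3cccc(OC)c3)cc2)C(C)C)c1` in this assay gives the limit > 21000 nM. Compound 2 `CCOC(=O)CCCCCOc1cccc(CN(C(=O)c2ccc(-c3cccc(OC(F)(F)F)c3)cc2)C(C)C)c1` in this assay gives the limit > 26000 nM. All three results are therefore limits rather than numbers, with one sitting at the limit of > 21000 nM in this assay, at which 1 of the 3 values shown sits, and two at the limit of > 26000 nM in this assay, at which 2 of the 3 values shown sit.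

Compound 4 `CCOC(=O)CCCCCOc1cccc(CN(C(=O)c2ccc(-c3cccc(CC(=O)O)c3)cc2)C(C)C)c1` differs from compound 3 by carboxymethyl in place of methylsulfonyl on an aromatic carbon. The measured steps that bear on substitution at this aromatic carbon are a step that the two limits leave unreadable from compound 1 to compound 2, a step that the two limits leave unreadable from compound 1 to compound 3 and a step that the two limits leave unreadable from compound 2 to compound 3; none yields a readable size, since every measured value is a limit. With three varied substituents at this position all ending at limits, no step beyond the scatter is expected in this assay for the change from compound 3 to compound 4, and the estimated step that the limit leaves unreadable from compound 3 to compound 4 reflects that. Compound 4 is expected to give about 30000 nM, within a range of 15000 nM to 60000 nM, most likely reported again as a limit.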

Compound 4, half-maximal effective concentration: > 26000 nM
Compound 4: only a limit was reported; the forecaster's own chance of this, stated with the estimate: 80%; the middle value lies beyond the limit too.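

No step can be read for compound 4: in this assay its result, like those of compound 1, compound 2 and compound 3, is only a limit. The compounds shown leave open whether substitution at this aromatic carbon shifts the effective concentration at all.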